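Shared core series: two limits and a sulfonyl analogue

The compounds below may be only part of what the source reports. "The series", "measured", "known", "first", "only" and "open" are said of these compounds alone.

compound 1 `COc1ccc(-c2[nH]c3cc(OC)cc(OC)c3c(=O)c2I)cc1` — > 86200 nM
compound 2 `COc1cc(OC)c2c(=O)cc(C(=O)Nc3ccc(N4CCN(C)CC4)cc3)[nH]c2c1` — > 19800 nM

In a functional assay on HepG2 cells (Homo sapiens) for antiproliferative activity, with a stated time of 72 h (on this read-out lower numbers stand for an effect already at smaller amounts and higher numbers for an effect only at larger amounts of compound), compound 1 gives only a limit, > 86200 nM. Compound 2 likewise gives only a limit, > 19800 nM, so no number stands for it (the limit of > 19800 nM in this assay, at which 1 of the 2 values shown sits). Among the measured compounds shown here, both measured values are limits, and no step between measured compounds is available. Compound 3 `COc1cc(OC)c2c(=O)cc(C(=O)Nc3ccc(S(=O)(=O)c4ccccc4)cc3)[nH]c2c1` differs from compound 2 by phenylsulfonyl in place of 4-methylpiperazin-1-yl on an aromatic carbon. With compound 2 at a limit, no direction can be read; the step from compound 2 to compound 3 in this assay is expected to stay within the scatter, a step that the limit leaves unreadable from compound 2 to compound 3. Compound 3 is estimated at 30000 nM, range 8000 nM to 100000 nM.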

Compound 3, half-maximal effective concentration: > 70600 nM
Compound 3 ended at the assay's limit; the forecaster's own chance of this, stated with the estimate: 60%; at least 2.3-fold (0.37 log units) between middle value and limit.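

Among the compounds shown here, compound 2 and compound 3 both stand at limits in this assay; no step between them can be read. The compounds shown leave open whether any change to the shared core gives a measured number rather than a limit in this assay.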